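The source may hold more compounds than are shown below. What is called first, only, known or untested is meant among the compounds shown, and "the series" means these compounds.

Measured so far:
- compound 1, `Cc1cccc(-c2cc(-c3ccc(Cl)o3)cc(-c3ccsc3)n2)c1`, 17900 nM in a functional assay on DU-145 cells (Homo sapiens) for cytotoxicity, in the presence of a further agent that is not named here; a lower number here means a stronger inhibitor, a higher number a weaker inhibitor
- compound 2, `Clc1ccc(-c2cc(-c3ccc(Cl)o3)cc(-c3ccsc3)n2)cc1`, 19500 nM in this assay

Compound 2 has the highest of these two numbers, and compound 1 lies within the scatter of it, so the two cannot be told apart. Compound 3, `Clc1ccc(-c2cc(-c3ccsc3)nc(-c3ccccn3)c2)o1`, differs from compound 2 by pyridin-2-yl in place of 4-chlorophenyl on an aromatic carbon. Going by the values given here, the only step that bears on this position is a 1.1-fold higher number from compound 1 to compound 2 (0.04 log units; within the scatter), an exchange of one aromatic ring for another at the same place without a change beyond the scatter. On that basis compound 3 is expected to show no step beyond the scatter, a 1.0-fold higher number from compound 2 to compound 3 (0.01 log units; within the scatter). The estimate for compound 3 is therefore 20000 nM, within 7000 nM to 60000 nM.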

Compound 3, half-maximal inhibitory concentration: 10900 nM
Compound 3: the middle estimate sits 1.8-fold (0.26 log units) above what was measured, within the range that was stated.
By their numbers in this assay, from the lowest: compounds 3, 1 and 2 (each within the scatter of the next).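

Putting pyridin-2-yl, a ring with a nitrogen and a hydrogen-bond acceptor, next to the ring nitrogen of the shared core produces no step beyond the scatter in this assay (a 1.8-fold lower number from compound 2 to compound 3 (0.25 log units; within the scatter); a 1.6-fold lower number from compound 1 to compound 3 (0.22 log units; within the scatter)). All three aromatic rings tried at this position therefore remain indistinguishable, whether or not the ring carries a nitrogen. No measurement here offers an explanation for these small differences. On these data alone, whether an amine, a carboxylic acid or a longer chain at this position would give a step beyond the scatter remains open.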